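Flipping One Sugar Centre in a Thiopurine Nucleoside

A few compounds are considered here, and "the series" means these few. Any claim that something is new, unique, unknown or untested is made for them only; others in the source may bear on it.

This piece follows two deoxyribose nucleosides of a shared core that carry a methylthio group, compound 2 `CSc1nc(N)nc2c1ncn2[C@@H]1C[C@H](O)[C@@H](CO)O1` and compound 3 `CSc1nc(N)nc2c1ncn2[C@H]1C[C@H](O)[C@@H](CO)O1`, alongside a benzylthio relative, compound 1 `Nc1nc(SCc2ccccc2)c2ncn([C@H]3C[C@H](O)[C@@H](CO)O3)c2n1`. The read-out is a functional assay on L1210 cells (Mus musculus) for inhibition, read by thymidine incorporation; on this read-out higher numbers stand for an effect only at larger amounts of compound and lower numbers for an effect already at smaller amounts. For compound 1 the outcome in this assay is "not determined" (no result reported). For compound 2 only a limit is reported: in this assay compound 2 gives > 100 uM, which marks the edge of what the assay can resolve rather than a number. That is where compound 2 stands: at the limit of > 100 uM in this assay, at which 1 of the 2 values shown sits, with no measured number to rank against anything else. Compound 3 differs from compound 2 only in configuration as drawn: the two compounds have the same atoms and bonds and differ only in configuration as drawn: 1 of 3 stereo elements differ; a stereocentre at a saturated ring carbon is drawn S in compound 2 and R in compound 3. No step between two measured compounds exists here, so no size of effect for such a flip has been shown. With compound 2 already at the limit, the step from compound 2 to compound 3 is expected to stay within the scatter, a step that the limit leaves unreadable from compound 2 to compound 3. Compound 3 is therefore estimated at 150 uM, between 30 uM and 600 uM, most likely reported again only as a limit.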

Compound 3, concentration for half-maximal effect: 27 uM
Compound 3: middle estimate off by 5.6-fold (0.74 log units), on the high side; the whole stated range lies above it.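

Turning one stereocentre at a saturated ring carbon from S to R gives an at least 3.7-fold lower number from compound 2 to compound 3 (0.56 log units; beyond the scatter) in this assay, a size for this change that the earlier compounds could not supply. Since no atom or bond changes, the difference in the read-out can be tied to that single centre alone: the fact that compounds 2 and 3 differ only in the configuration as drawn. The step is only a minimum, and its full size cannot be stated because one of its two ends is a limit of the assay rather than a number: the limit of > 100 uM in this assay, at which 1 of the 3 values shown sits.

Compound 1 stands at "not determined" (no result reported) in this assay, so it adds no reading on whether the benzylthio group behaves like the methylthio group, or on how the configuration at this centre plays out with a larger group on the core. Also open, on these data alone, is whether the same flip would have a similar effect with a longer chain in place of the methylthio group or with an amine there, and what the two stereo elements left unchanged contribute to the read-out.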